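The source may hold more compounds than are shown below. What is called first, only, known or untested is meant among the compounds shown, and "the series" means these compounds.

Four compounds share one core and differ in a single part of the structure: compound 1 (`O=C(O)C12CCC(C(=O)N3CC[C@](c4ccc(C(F)(C(F)(F)F)C(F)(F)F)cc4)(S(=O)(=O)c4ccc(F)cc4)C3)(CC1)C2`), compound 2 (`CS(=O)(=O)C1CCC(C(=O)N2CC[C@](c3ccc(C(F)(C(F)(F)F)C(F)(F)F)cc3)(S(=O)(=O)c3ccc(F)cc3)C2)CC1`), compound 3 (`CCC1(C(=O)N2CC[C@](c3ccc(C(F)(C(F)(F)F)C(F)(F)F)cc3)(S(=O)(=O)c3ccc(F)cc3)C2)CCS(=O)(=O)CC1`) and compound 4 (`O=C(N1CC[C@](c2ccc(C(F)(C(F)(F)F)C(F)(F)F)cc2)(S(=O)(=O)c2ccc(F)cc2)C1)C1(CO)CCS(=O)(=O)CC1`). In an ADME assay on microsomes from liver (Mus musculus) for metabolic stability, with a stated time of 10 min (a higher number here means that more of the compound is left, a lower number that less of the compound is left), compound 3 gives 0% as its reading, the only single, unambiguous number available for this set. Compound 1 gives "not determined" (no result reported) in this measurement, so it offers no guide. Within the data shown here, compound 2 shows 69%; "not determined" (no result reported) (2 entries) across its entries, which means its one number stands beside an entry without a result.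

The step to compound 4 looks small on paper. It is hydroxy in place of methyl on a saturated chain carbon bound to a saturated ring carbon in the counted comparison, with hydroxy in place of methyl on a saturated chain carbon bound to a saturated ring carbon, so that ethyl becomes hydroxymethyl. Among the measured compounds shown here, no measured pair here shows what such a swap does, so any forecast is rough. Compound 3 at 0% has no room to fall, and compound 2 with 69%; "not determined" (no result reported) (2 entries) suggests that a compound on this core can keep a sizeable share intact. The estimated change a number 35 percentage points higher from compound 3 to compound 4 (beyond the scatter) is upward and beyond the usual scatter. The expected value for compound 4 is 35% within an estimated range from 5% to 75% in this measurement.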

Compound 4, percent of the compound remaining: 31%
Compound 4: the middle estimate sits 4 percentage points above what was measured, and the stated range covers the measured number.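

In this assay, hydroxy in place of methyl on a saturated chain carbon bound to a saturated ring carbon, which turns ethyl into hydroxymethyl, gives a number 31 percentage points higher from compound 3 to compound 4 (beyond the scatter). Among these compounds, this is the first measured pair on the shared core that differs in one place, and it shows that this position can shift the read-out clearly. A swap this small separates a compound of which nothing is left from one of which a measurable share remains, though nothing in the data shown explains how the swap does this.

On these data alone, what remains open is whether the gain belongs to hydroxymethyl in particular or would also appear with other groups at this place, such as aminomethyl, methoxymethyl or a longer chain like propyl. A single pair also cannot tell whether the same swap would raise the number in the same way when the rest of the acyl group on the shared core is different.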